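Methyl on the aromatic ring of the shared core

The compounds below may be only part of what the source reports. "The series", "measured", "known", "first", "only" and "open" are said of these compounds alone.

Measured so far:
compound 1, `CC1(C)CCC[C@]2(C)[C@@H](Cc3c(O)cccc3O)[C@](C)(O)CC[C@@H]12`: 16000 nM
compound 2, `CC1(C)CCC[C@]2(C)[C@@H](Cc3cc(C(=O)O)ccc3O)[C@](C)(O)CC[C@@H]12`: 50000 nM
compound 3, `Cc1cc(O)cc(O)c1C[C@@H]1[C@@]2(C)CCCC(C)(C)[C@@H]2CC[C@@]1(C)O`: 11300 nM

The three compounds were run in a functional assay on MCF7 cells (Homo sapiens) for inhibition, read by MTT assay, with a stated time of 72 h; a lower number here means that less compound is needed, a higher number that more compound is needed for the effect. Compound 1 stands second highest of the three numbers; the nearest value is that of compound 3, which lies within the usual scatter of compound 1, while compound 2 lies beyond it with the higher number of the set.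

Compound 4, `Cc1cc(O)c(C[C@@H]2[C@@]3(C)CCCC(C)(C)[C@@H]3CC[C@@]2(C)O)c(O)c1`, is not yet measured. Relative to compound 1 the change is methyl in place of hydrogen on an aromatic carbon.

For the measured compounds named here, no step between measured compounds is available that would show what this change does. Compound 3 also carries a methyl on the aromatic ring, in a different place, and its value sits within the scatter of compound 1; this is the only hint, and it points to no movement beyond the scatter. The expectation is therefore that a 1.2-fold lower number from compound 1 to compound 4 (0.09 log units; within the scatter) stays within the usual scatter. Compound 4 is expected to give 13000 nM, with a range from 6000 nM to 30000 nM in this assay.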

Compound 4, half-maximal effective concentration: 10100 nM
The estimate for compound 4 lay 1.3-fold (0.11 log units) above the measured number; measured number inside the range.
By their numbers in this assay, from the lowest: compounds 4, 3 and 1 (each within the scatter of the next); then compound 2.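

In this assay, methyl in place of hydrogen on the aromatic carbon meta to two hydroxy groups and para to a large group gives a 1.6-fold lower number from compound 1 to compound 4 (0.20 log units; within the scatter). For the compounds shown here, this is the only direct reading of the change at this position, and it shows that the added methyl leaves the number indistinguishable from that of the unsubstituted ring within repeat measurements. The data on hand offer no measurement that would explain this outcome.

Still open, on these data alone, is whether an ethyl group, a fluorine atom or an amine on this same aromatic carbon would move the number beyond the scatter. Also open, as far as these compounds go, is whether a methoxy group in place of either hydroxy group would change how compound 4 reads in this assay.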